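Vinyl to Cyclobutyl on a Charged Pyridinium Chain

This account rests on a few compounds, and the source may have more. Where it says the series, first, only, none or still open, it means among the compounds named here.

Of the compounds shown here, two sharing the same dimethoxy-substituted core have been measured in a physicochemical assay for solubility; a lower number here means a less soluble compound, a higher number a more soluble compound. Compound 1 `COc1cc2cc(C(O)C3CC[N+](C)(Cc4ccccc4)CC3)sc2cc1OC` gives 2000 ug/mL in this assay. Compound 2 `C=CC[n+]1ccc(CCC(=O)c2cc3cc(OC)c(OC)cc3s2)cc1` gives 25000 ug/mL, the higher of the two numbers, and its gap to compound 1 lies beyond the scatter of repeated measurements. Compound 3 `COc1cc2cc(C(=O)CCc3cc[n+](CC4CCC4)cc3)sc2cc1OC` has not yet been measured. It differs from compound 2 in one place: cyclobutyl in place of vinyl on a saturated chain carbon bound to an aromatic nitrogen. Within the data shown here, no measured pair in this set shows the effect of such a change, so the expectation rests on the structural change alone. Enlarging the side chain on the charged ring by two carbons closed into a small ring is expected to lower the number modestly, by the step of a 3.1-fold lower number from compound 2 to compound 3 (0.49 log units; beyond the scatter) from the value of compound 2. Compound 3 is therefore estimated at 8000 ug/mL, within a range from 2500 ug/mL to 25000 ug/mL.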

Compound 3, solubility: 6000 ug/mL
Compound 3: middle estimate off by 1.3-fold (0.12 log units), on the high side; measured number inside the range.
By their numbers in this assay, from the lowest: compound 1; then compound 3; then compound 2.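

On a saturated chain carbon bound to an aromatic nitrogen, cyclobutyl in place of vinyl gives a 4.2-fold lower number from compound 2 to compound 3 (0.62 log units; beyond the scatter) in this assay. Among these compounds, this is the first pair in the set that differs in one place, so it is the first reading of what a change at this position alone does to the number. A swap confined to this small carbon-only group, with no hydrogen-bond donors or acceptors on either side and no net charge on the group itself, still moves the read-out beyond the scatter. No measurement here bears on why the number falls. The pair cannot tell whether the step follows from the lost double bond, the larger carbon group or the closed ring, and an open butyl chain or a hydroxyethyl group at this place remains an open comparison.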